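The compounds below may be only part of what the source reports. "The series", "measured", "known", "first", "only" and "open" are said of these compounds alone.

Going by the values given here, compound 2 `CO[C@H]1CC[C@H](CN2CC(=O)Nc3ncc(-c4ccc(C(C)(C)O)nc4)nc32)CC1` stands highest of the two numbers so far in a functional assay on the whole organism (PC-3 cells) for inhibition, with Mus musculus as the target, in a xenograft, with a stated time of 4 h, at a dose of 100 mg/kg by the oral route (on this read-out higher numbers stand for more inhibition at the one dose given (going by the name of the read-out) and lower numbers for less inhibition), giving 80%; compound 1 `CO[C@H]1CC[C@@H](N2CC(=O)Nc3ncc(-c4ccc(C(C)(C)O)nc4)nc32)CC1` gives 54%. Among the compounds with values here, the only step bearing on the next compound is a number 26 percentage points higher from compound 1 to compound 2 (beyond the scatter). Compound 3 `CO[C@H]1CC[C@H](N2CC(=O)Nc3ncc(-c4ccc(C(C)(C)O)nc4)nc32)CC1` carries the change (4-methoxycyclohexyl in place of (4-methoxycyclohexyl)methyl on a nitrogen on an aromatic ring in a ring), which undoes that step, so a fall of similar size in this assay is expected, a number 25 percentage points lower from compound 2 to compound 3 (beyond the scatter). Compound 1 also bears 4-methoxycyclohexyl on that nitrogen, and its value of 54% supports this. The estimate for compound 3 in this assay is 55%, with a range from 35% to 75%.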

Compound 3, a percentage reported as inhibition, in the whole organism at one dose (the size of the read-out at that dose, not a potency): 90%
Compound 3: middle estimate off by 35 percentage points, on the low side; the measured number lies above the stated range.
By their numbers in this assay, from the lowest: compound 1; then compounds 2 and 3 (each within the scatter of the next).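

At this position, on a nitrogen on an aromatic ring in a ring, configuration alone moves the read-out in this assay: there is a number 36 percentage points higher from compound 1 to compound 3 (beyond the scatter). This step involves no change of group: the fact that compounds 1 and 3 differ only in the configuration as drawn. With 4-methoxycyclohexyl in place of (4-methoxycyclohexyl)methyl there is a number 10 percentage points higher from compound 2 to compound 3 (within the scatter), so the longer group shows no edge over 4-methoxycyclohexyl drawn as in compound 3.

From the compounds shown here alone, whether the methoxy group is needed remains open; a hydroxyl or an amine on the cyclohexyl ring would address this. A single dose also gives no potency.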